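A few compounds are considered here, and "the series" means these few. Any claim that something is new, unique, unknown or untested is made for them only; others in the source may bear on it.

The measured compounds:

Compound 1, `COc1cc(OC)cc(-c2cc3ccccc3c(-c3cccc(OC)c3)n2)c1`: 1170 nM
Compound 2, `COc1cc(OC)cc(-c2cc3ccccc3c(-c3cccc(N)c3)n2)c1`: 4080 nM
Compound 3, `COc1cccc(-c2nc(-c3ccc(OC)c(OC)c3)cc3cc(C)ccc23)c1`: 1840 nM

These three numbers come from a functional assay on HCT-15 cells (Homo sapiens) for cytotoxicity, read by CCK-8 assay and cell counting, with a stated time of 72 h; a higher number here means a weaker inhibitor, a lower number a stronger inhibitor. Compound 1 and compound 2 share the same core and differ in one place only: amino in place of methoxy on an aromatic carbon. That single change gave a 3.5-fold higher number from compound 1 to compound 2 (0.54 log units; beyond the scatter), so the compound carrying the amino group is the weaker inhibitor of the pair.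

Compound 3 is built on a different core, and the difference between the two cores is not broken down here. Its value and that of compound 1 lie within the usual scatter of each other, so no order can be read between them. Against compound 2 the number for compound 3 is lower by more than the scatter.

Compound 4, `COc1ccc(-c2cc3cc(C)ccc3c(-c3cccc(N)c3)n2)cc1OC`, is the counterpart of compound 3 in the same way that compound 2 is the counterpart of compound 1: it differs from compound 3 by amino in place of methoxy on an aromatic carbon. The place of the change is the same, word for word, as between compound 1 and compound 2, so this is the same change made on the other core. For the measured compounds named here, it has been seen only once so far, and there is no second example to show whether its size carries over between the two cores. The natural expectation is that the step repeats: from compound 3 to compound 4 an estimated 3.5-fold higher number from compound 3 to compound 4 (0.54 log units; beyond the scatter) in this assay. That rests on the earlier step of a 3.5-fold higher number from compound 1 to compound 2 (0.54 log units; beyond the scatter) and on the starting value of compound 3, 1840 nM. Compound 4 is therefore estimated at 6400 nM. Allowing for the single precedent and the change of core, the expected range for compound 4 runs from 3000 nM to 14000 nM.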

Compound 4, half-maximal inhibitory concentration: 2700 nM
For compound 4 the middle estimate is 2.4-fold (0.37 log units) above the measured one; the whole stated range lies above it.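

Carrying the same swap of amino for methoxy to the core of compound 3 gave a 1.5-fold higher number from compound 3 to compound 4 (0.17 log units; within the scatter) in this assay, so on this core the effect of the change cannot be told apart from the ordinary spread of repeated measurements. Set beside the step on the core of compound 1, this result does not establish that the two cores respond differently: the same change on two cores in this assay, a 3.5-fold higher number (0.54 log units; beyond the scatter) from compound 1 to compound 2 and a 1.5-fold higher number (0.17 log units; within the scatter) from compound 3 to compound 4, 2.4-fold (0.38 log units) apart, within the scatter of two such steps With only one matched pair on each core, the data show neither that the size of the step depends on the core nor that it carries over unchanged, and a single shared modest effect remains as possible as two different ones.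

The compounds shown leave open how other groups in the same place would behave on either core, such as a hydroxyl, a fluorine or a longer chain like ethoxy in place of methoxy. Also open, from the compounds shown here alone, is whether the swap from 3-methoxyphenyl to 3-aminophenyl would give a step of similar size on a third core, which would help show whether the first step or the second is the more typical.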